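Fluoro in Place of Methoxy on an Aromatic Carbon

A few compounds are considered here, and "the series" means these few. Any claim that something is new, unique, unknown or untested is made for them only; others in the source may bear on it.

In a functional assay on A549 cells (Homo sapiens) for antiproliferative activity, read by MTT assay, with a stated time of 72 h (a higher number here means a weaker inhibitor, a lower number a stronger inhibitor), compound 1 (`Cc1nc(C)c(/C=C/C(=O)/C=C/c2ccccc2O)nc1C`) gives 4780 nM. Compound 2 (`COc1ccc(/C=C/C(=O)/C=C/c2nc(C)c(C)nc2C)cc1`) gives 3500 nM, and these two numbers lie within the usual scatter of each other, so neither can be ranked over the other. Compound 3 (`Cc1nc(C)c(/C=C/C(=O)/C=C/c2ccc(F)cc2)nc1C`) has fluoro in place of methoxy on an aromatic carbon, para to a large group (fluoro in place of methoxy on an aromatic carbon). Among the compounds with values here, no measured pair shows a comparable change, so in this assay no shift beyond the scatter is expected, and the estimated step is small (a 1.2-fold lower number from compound 2 to compound 3 (0.07 log units; within the scatter)). For compound 3, the estimated value is 3000 nM, with an expected range of 1200 nM to 7500 nM.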

Compound 3, half-maximal inhibitory concentration: 5900 nM
The estimate for compound 3 lay 2.0-fold (0.29 log units) below the measured number; measured number inside the range.
By their numbers in this assay, from the lowest: compounds 2, 1 and 3 (each within the scatter of the next).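

In this assay the swap of methoxy for fluoro gives a 1.7-fold higher number from compound 2 to compound 3 (0.23 log units; within the scatter) and so leaves no shift that can be told from the scatter, even though fluoro has one heavy atom fewer and no hydrogen-bond acceptor. The change from 2-hydroxyphenyl to 4-fluorophenyl gives a 1.2-fold higher number from compound 1 to compound 3 (0.09 log units; within the scatter), so all three compounds remain unranked. No measurement on hand bears on the reason for this result. As far as these compounds go, whether an amine or a carboxylic acid on this aromatic carbon would move the number beyond the scatter stays open.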